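Methoxy to nitro on the benzyl-triazole series

The compounds below may be only part of what the source reports. "The series", "measured", "known", "first", "only" and "open" are said of these compounds alone.

Measured in a functional assay on Hep 3B2 cells (Homo sapiens) for cytotoxicity, read by MTT assay, with a stated time of 6 days; a lower number here means a stronger inhibitor, a higher number a weaker inhibitor:
- compound 1 `COc1ccc2c(c1)N(Cc1cn(Cc3ccccc3)nn1)C(=O)CO2`: > 100000 nM (a limit)
- compound 2 `CC(C)(C)c1ccc(Cn2cc(CN3C(=O)COc4ccccc43)nn2)cc1`: 25600 nM
- compound 3 `COc1ccc(Cn2cc(CN3C(=O)COc4ccccc43)nn2)cc1`: > 100000 nM (a limit)

Compound 3 sits at the limit of > 100000 nM in this assay, at which 2 of the 3 values shown sit. It therefore offers a limit and not a number to start from.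

The next compound is compound 4 `O=C1COc2ccccc2N1Cc1cn(Cc2ccc([N+](=O)[O-])cc2)nn1`, with nitro in place of methoxy on an aromatic carbon, para to a large group: nitro in place of methoxy on an aromatic carbon.

One measured step changes the group at this place: an at least 3.9-fold higher number from compound 2 to compound 3 (0.59 log units; beyond the scatter). Compound 2, carrying tert-butyl there, gives 25600 nM, so a group at this place can bring a number into range. Going by the values given here, no measured compound carries nitro, so the direction rests on that single step.

A modest move toward a lower number is expected in this assay, no larger than that measured step, and a further limit would not surprise. In numbers, the expected step is an at least 1.4-fold lower number from compound 3 to compound 4 (0.15 log units; that floor lies within the scatter). Compound 4 is estimated at 70000 nM, with an expected range of 25000 nM to 200000 nM.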

Compound 4, half-maximal inhibitory concentration: 29600 nM
For compound 4 the middle estimate is 2.4-fold (0.37 log units) above the measured one, and the stated range covers the measured number.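

In this assay, the change from 4-methoxyphenyl to 4-nitrophenyl gives an at least 3.3-fold lower number from compound 3 to compound 4 (0.52 log units; beyond the scatter), so nitro joins tert-butyl as a second group that brings a number into range at this place. Nitro and tert-butyl cannot be told apart here, with a 1.2-fold higher number from compound 2 to compound 4 (0.06 log units; within the scatter), so among the three groups compared at this place, only methoxy stands apart. The value of compound 3 is a limit, not a number, so the size of the step from methoxy is only a floor: the limit of > 100000 nM in this assay, at which 2 of the 4 values shown sit.

From the compounds shown here alone, what an amine or a carboxylic acid would give at this place stays open, as does a longer chain. Also open, going by these compounds, is whether any other group here would reach a number clearly lower than those of compound 2 and compound 4.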